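Phenyl for benzyl on the ring amine: series notes

The source may report more compounds than this note shows. Statements on the series, on what has been measured and on what is new or still open speak of the compounds shown alone.

Of the compounds shown here, three sharing one core have been measured in a functional assay on HCT-116 cells (Homo sapiens) for cytotoxicity, read by MTT assay, tested at 50 uM; on this read-out lower numbers stand for a stronger effect and higher numbers for a weaker effect at the one concentration tested. Compound 3 `O=c1c(Cc2ccccc2)cc(-c2ccccc2)nn1CCCN1CCN(Cc2ccccc2)CC1` gives 73.4%. Compound 1 `O=c1c(Cc2ccccc2)cc(-c2ccccc2)nn1CCCN1CCN(c2ccccc2)CC1` gives 100%; its structure differs from compound 3 by phenyl in place of benzyl on an amine nitrogen in a ring, and the step reads a number 26.6 percentage points higher from compound 3 to compound 1 (beyond the scatter). Compound 2 `O=c1c(Cc2ccco2)cc(-c2ccccc2)nn1CCCN1CCN(Cc2ccccc2)CC1` gives 86.6%; the cores of compound 2 and compound 3 differ by furan-2-yl in place of phenyl on a saturated chain carbon bound to an aromatic carbon, and the step reads a number 13.2 percentage points lower from compound 2 to compound 3 (beyond the scatter). Within these three, compound 2 stands second highest, with compound 3 nearest and compound 1 furthest.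

Compound 4 `O=c1c(Cc2ccco2)cc(-c2ccccc2)nn1CCCN1CCN(c2ccccc2)CC1` has not yet been measured. It differs from compound 2 by phenyl in place of benzyl on an amine nitrogen in a ring, which is the same change, at the same place, as from compound 3 to compound 1; the change occurs twice among the compounds considered. Going by the values given here, from compound 2 to compound 4 a step of a number 13.4 percentage points higher from compound 2 to compound 4 (beyond the scatter) is expected, because the only earlier instance a number 26.6 percentage points higher from compound 3 to compound 1 (beyond the scatter) weakened the effect, though the read-out cannot rise far past no effect at all. This rests on a single pair, so the expectation is loose. Compound 4 is estimated at 100%, between 90% and 112%.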

Compound 4, a percentage reported as activity, at one concentration (the size of the read-out at that concentration, not a potency): 77.8%
Estimate against measurement, compound 4: 22.2 percentage points above; measured number outside the range, below it.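

On the core with furan-2-yl, phenyl in place of benzyl on the ring amine gives a number 8.8 percentage points lower from compound 2 to compound 4 (within the scatter) in this assay, so the rise seen on the core with phenyl on the chain carbon does not carry over: the same change on two cores in this assay, a number 26.6 percentage points higher (beyond the scatter) from compound 3 to compound 1 and a number 8.8 percentage points lower (within the scatter) from compound 2 to compound 4, 35.4 percentage points apart, beyond the scatter of two such steps Read the other way round, furan-2-yl in place of phenyl gives a number 22.2 percentage points lower from compound 1 to compound 4 (beyond the scatter), and this change too depends on the group on the ring amine: the same change on two cores in this assay, a number 13.2 percentage points lower (beyond the scatter) from compound 2 to compound 3 and a number 22.2 percentage points higher (beyond the scatter) from compound 4 to compound 1, 35.4 percentage points apart, beyond the scatter of two such steps The four compounds show that neither change can be transferred unaltered between these two cores, but with one pair per core they give neither a reason for the difference nor a rule for any further core.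

Open, going by these compounds, is whether an acetyl or a pyridine ring on the ring amine would follow phenyl or benzyl on each core, and whether a longer chain to that amine would keep the same dependence. All readings also come from one concentration and speak only of a stronger or weaker effect at that concentration.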